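Aryl piperazine variation on the shared core in gastric cells

The compounds below may be only part of what the source reports. "The series", "measured", "known", "first", "only" and "open" are said of these compounds alone.

Measured so far:
compound 1 `S=c1oc(-c2ccc3c(c2)OCCO3)nn1CN1CCN(C(c2ccccc2)c2ccccc2)CC1`, > 50000 nM
compound 2 `Cc1ccc(N2CCN(Cn3nc(-c4ccc5c(c4)OCCO5)oc3=S)CC2)c(C)c1`, 28300 nM
compound 3 `COc1ccccc1N1CCN(Cn2nc(-c3ccc4c(c3)OCCO4)oc2=S)CC1`, 19500 nM

In a functional assay on BGC-823 cells (Homo sapiens) for antiproliferative activity, read by MTT assay, with a stated time of 48 h (a lower number here means a stronger inhibitor, a higher number a weaker inhibitor), compound 2 gives the highest of the two numbers; compound 3 sits nearest, with a 1.5-fold lower number from compound 2 to compound 3 (0.16 log units; within the scatter). For compound 1 the value is a limit of the assay, (the limit of > 50000 nM in this assay, at which 1 of the 3 values shown sits), not a number.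

Compound 4 `COc1cccc(N2CCN(Cn3nc(-c4ccc5c(c4)OCCO5)oc3=S)CC2)c1` differs from compound 2 by 3-methoxyphenyl in place of 2,4-dimethylphenyl on an amine nitrogen in a ring. Among the compounds with values here, the only measured step on this position is the one from compound 2 to compound 3, and it stayed within the scatter. A step of similar size is therefore expected for compound 4, a 1.4-fold lower number from compound 2 to compound 4 (0.15 log units; within the scatter), in this assay. Compound 4 is estimated at 20000 nM, between 8000 nM and 50000 nM.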

Compound 4, half-maximal inhibitory concentration: > 50000 nM
Compound 4 gave a limit, no number; the forecaster's own chance of this, stated with the estimate: 25%; middle value at least 2.5-fold (0.39 log units) from the limit.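

Within the data shown here, replacing 2-methoxyphenyl with 3-methoxyphenyl on the amine nitrogen in the ring gives the first step at this position that lies beyond the scatter, in this assay: an at least 2.5-fold higher number from compound 3 to compound 4 (0.40 log units; beyond the scatter). Replacing 2,4-dimethylphenyl with 3-methoxyphenyl gives an at least 1.7-fold higher number from compound 2 to compound 4 (0.24 log units; that floor lies within the scatter), so this floor does not separate those two groups. Compound 4 carries a limit of the assay rather than a number, leaving the full size of both steps unknown: the limit of > 50000 nM in this assay, at which 2 of the 4 values shown sit.

Still open is whether a phenyl carrying an amine or a carboxylic acid on this nitrogen would give a lower number than the groups shown.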